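The source may hold more compounds than are shown below. What is called first, only, known or untested is meant among the compounds shown, and "the series" means these compounds.

Compound 1 `O=C(Nc1nnc(-c2ccc(Cl)cc2)s1)c1c(F)cccc1F`: > 5010 nM in a functional assay on the whole organism (integument) for inhibition, with Chilo suppressalis as the target, read by scintillation counting, with a stated time of 72 h (a lower number here means a stronger inhibitor, a higher number a weaker inhibitor), a limit of the assay.
Compound 2 `Cc1cccc(C)c1C(=O)Nc1nnc(-c2ccc(Cl)cc2)s1`: 69.2 nM in this assay.
Compound 3 `O=C(Nc1nnc(-c2ccc(Cl)cc2)s1)c1ccccc1Br`: > 5010 nM in this assay, a limit of the assay.

Compound 3 therefore stands at the limit of > 5010 nM in this assay, at which 2 of the 3 values shown sit; of the three, only compound 2 gives a number, and where compound 3 actually lies beyond that limit cannot be told. Compound 4 `CCOc1ccccc1C(=O)Nc1nnc(-c2ccc(Cl)cc2)s1` differs from compound 3 by ethoxy in place of bromo on an aromatic carbon. Among the compounds with values here, no step between measured compounds is known, so the expectation rests on the three values alone: compound 2 shows that a substituted ring of this kind can give a number, while compound 1 and compound 3 did not. The step from compound 3 to compound 4 is expected to be an at least 3.3-fold lower number from compound 3 to compound 4 (0.52 log units; beyond the scatter), toward stronger inhibition but uncertain. Compound 4 is estimated at 1500 nM, within 300 nM to 8000 nM.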

Compound 4, half-maximal inhibitory concentration: > 5010 nM
Compound 4: no number, only a limit (the forecaster's own chance of this, stated with the estimate: 40%); middle value at least 3.3-fold (0.52 log units) from the limit.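

Within the data shown here, compound 3 and compound 4 both stop at a limit of the assay, so no step between them can be read. The compounds shown leave open how far beyond that limit either one lies.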